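The source may report more compounds than this note shows. Statements on the series, on what has been measured and on what is new or still open speak of the compounds shown alone.

Compounds in this series share the core shown by compound 1 `O=C(Nc1cccc(Nc2ncc(F)c(Nc3ccc(F)cc3)n2)c1)c1ccccc1` and differ only in the group on the carbonyl carbon. In a functional assay on KBVIN cells (Homo sapiens) for antiproliferative activity, read by sulforhodamine B assay, with a stated time of 3 days (a lower number here means a stronger inhibitor of growth, a higher number a weaker inhibitor of growth), compound 1 gives only a limit, > 10000 nM. Compound 2 `O=C(Nc1cccc(Nc2ncc(F)c(Nc3ccc(F)cc3)n2)c1)c1ccncc1` gives 4570 nM. Compound 3 `COCC(=O)Nc1cccc(Nc2ncc(F)c(Nc3ccc(F)cc3)n2)c1` gives 3940 nM, the lowest of the two numbers, though the step of a 1.2-fold lower number from compound 2 to compound 3 (0.06 log units; within the scatter) is within the scatter. Compound 4 `O=C(Nc1cccc(Nc2ncc(F)c(Nc3ccc(F)cc3)n2)c1)c1cccc([N+](=O)[O-])c1` carries the change (3-nitrophenyl in place of methoxymethyl on a carbonyl carbon). For the measured compounds named here, the steps that bear on it are an at least 2.5-fold lower number from compound 1 to compound 3 (0.40 log units; beyond the scatter) and a 1.2-fold lower number from compound 2 to compound 3 (0.06 log units; within the scatter): both moves toward methoxymethyl ran to lower numbers, one beyond the scatter, one within it. Returning to an aryl on the carbonyl carbon is therefore expected to raise the number for compound 4, a 1.8-fold higher number from compound 3 to compound 4 (0.25 log units; within the scatter), with a fair chance of a limit. Compound 4 is estimated at 7000 nM, range 2500 nM to 20000 nM.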

Compound 4, concentration for 50% growth inhibition: 11400 nM
The estimate for compound 4 lay 1.6-fold (0.21 log units) below the measured number, and the stated range covers the measured number.
By their numbers in this assay, from the lowest: compounds 3 and 2 (each within the scatter of the next); then compound 4.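

In this assay, the group on the carbonyl carbon now produces readable separations beyond the scatter: a 2.9-fold higher number from compound 3 to compound 4 (0.46 log units; beyond the scatter) and a 2.5-fold higher number from compound 2 to compound 4 (0.40 log units; beyond the scatter). The two ring-bearing groups, pyridin-4-yl and 3-nitrophenyl, therefore do not read alike at this position. Compound 1 stands only as a limit, so its step to compound 4, nitro in place of hydrogen on an aromatic carbon, cannot be read: the limit of > 10000 nM in this assay, at which 1 of the 4 values shown sits.

Still open, going by these compounds, is whether a longer ether chain or an aminomethyl group on the carbonyl carbon would give a number clearly apart from compound 3. Also open, on these data alone, is whether an amine in place of the nitro would read differently from compound 4.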